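The source may report more compounds than this note shows. Statements on the series, on what has been measured and on what is new or still open speak of the compounds shown alone.

Compound 2 `CCCCCCCCCCCCCCCCOP(=O)(O)OCCSC(=S)N1CCN(C)CC1` gives 49300 nM in a functional assay on DU-145 cells (Homo sapiens) for inhibition, read by MTT assay, with stated times of 18 h and 4 h (a higher number here means a weaker inhibitor, a lower number a stronger inhibitor), and compound 1 `CCCCCCCCOP(=O)(O)OCCSC(=S)N1CCCC1` gives 47100 nM there as well. These two numbers lie within the usual scatter of each other, so compound 2 stands level with compound 1 even though their structures differ in more than one place. Compound 3 `CCCCCCCCOP(=O)(O)OCCSC(=S)N1CCN(C)CC1` is still unmeasured. It comes from compound 2 by one change (hydrogen in place of octyl on a saturated chain carbon, eight bonds along the chain from an oxygen on an unsaturated carbon): hydrogen in place of octyl on a saturated chain carbon, eight bonds along the chain from an oxygen on an unsaturated carbon. Going by the values given here, no measured pair shows this change alone. Compound 3 shares its chain with compound 1 at 47100 nM and the rest of its structure with compound 2 at 49300 nM so no step beyond the scatter is expected in this assay in either direction. The estimated 1.0-fold higher number from compound 2 to compound 3 (0.01 log units; within the scatter) is therefore small. For compound 3 the expected value is 50000 nM with an estimated range of 20000 nM to 120000 nM in this measurement.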

Compound 3, half-maximal inhibitory concentration: > 100000 nM
Compound 3: a limit, no number; the forecaster's own chance of this, stated with the estimate: 15%; middle value at least 2.0-fold (0.30 log units) from the limit.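

Compound 3 gives no number in this assay, only a limit: the limit of > 100000 nM in this assay, at which 1 of the 3 values shown sits. Hydrogen in place of octyl on the saturated chain carbon gives an at least 2.0-fold higher number from compound 2 to compound 3 (0.30 log units; that floor lies within the scatter), so the true step could be larger, but this floor alone does not establish a change beyond the scatter. With the chain held constant, 4-methylpiperazin-1-yl in place of pyrrolidin-1-yl on the thiocarbonyl carbon gives an at least 2.1-fold higher number from compound 1 to compound 3 (0.32 log units; beyond the scatter), which separates two compounds with the same chain, something the level pair of compound 1 and compound 2 could not do.

On these data alone, how far the number rises once the chain is shortened remains open, as the limit hides the size of that step. Also open, as far as these compounds go, is how a decyl or dodecyl chain, or a morpholin-4-yl group on the thiocarbonyl carbon, would read in this assay.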